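This account rests on a few compounds, and the source may have more. Where it says the series, first, only, none or still open, it means among the compounds named here.

Compound 1 `O=C(Nc1nn[nH]n1)c1cccnc1` and compound 2 `CC(C)c1ccnc(C(=O)Nc2nn[nH]n2)c1` share one core. In a functional assay on the whole organism for inhibition, with Rattus norvegicus as the target, at a dose of 3 mg/kg by the oral route (a higher number here means a stronger effect of the compound at the dose given, a lower number a weaker effect), compound 1 gives 4%, while compound 2 gives 34%; compound 2 stands highest of the two numbers, and its nearest neighbour, compound 1, lies a gap beyond the scatter away. Compound 3 `O=C(Nc1nn[nH]n1)c1cc(Br)ccn1` is not yet measured. It differs from compound 2 in one place (bromo in place of isopropyl on an aromatic carbon). Among the measured compounds shown here, no step between measured compounds covers a change of this kind, so any expectation rests on the two values alone. Compound 3 is estimated at 20% in this assay, with a range of 5% to 40%. That amounts to an expected step of a number 14 percentage points lower from compound 2 to compound 3 (beyond the scatter), downward and near the edge of the scatter.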

Compound 3, a percentage reported as inhibition, in the whole organism at one dose (the size of the read-out at that dose, not a potency): 34%
The estimate for compound 3 lay 14 percentage points below the measured number; low and high end bracket the measured number.
By their numbers in this assay, from the lowest: compound 1; then compounds 2 and 3 (each within the scatter of the next).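

Bromo in place of isopropyl, on the aromatic carbon opposite the ring nitrogen, gives in this assay no change at the digits printed from compound 2 to compound 3 (within the scatter). At this position, then, the single bromine atom and the three-carbon isopropyl group cannot be told apart at this dose, so the read-out here does not track the heavy-atom count across this one pair. Nothing available explains this match. From the compounds shown here alone, whether an amine, a methoxy group or a longer chain on the same carbon would read alike remains open. A single oral dose also gives no potency for compound 2 or compound 3.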